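The compounds below may be only part of what the source reports. "The series", "measured", "known", "first", "only" and "open" are said of these compounds alone.

Working notes on the series. Compound 3 `Cc1ccc(OCC(=O)NNC(=O)c2cc3ccccc3oc2=O)c(C(=O)c2ccc(Br)cc2)c1` gives 92200 nM in a functional assay on DLA cells (Mus musculus) for cytotoxicity, read by MTT assay, with a stated time of 48 h; a higher number here means a weaker inhibitor, a lower number a stronger inhibitor — the highest of the three numbers, though every gap to the others lies within the scatter. Compound 1 `Cc1ccc(OCC(=O)NNC(=O)c2cc3ccccc3oc2=O)c(C(=O)c2ccccc2)c1` gives 86400 nM in this assay, and compound 2 `Cc1ccc(OCC(=O)NNC(=O)c2cc3ccccc3oc2=O)c(C(=O)c2ccc(Cl)cc2)c1` gives 59100 nM. The steps among them are all small: a 1.5-fold lower number from compound 1 to compound 2 (0.16 log units; within the scatter), a 1.1-fold higher number from compound 1 to compound 3 (0.03 log units; within the scatter), and a 1.6-fold higher number from compound 2 to compound 3 (0.19 log units; within the scatter). Compound 4 `Cc1ccc(C(=O)c2cc(C)ccc2OCC(=O)NNC(=O)c2cc3ccccc3oc2=O)cc1` is the next member; the change is methyl in place of bromo on an aromatic carbon. The three steps that bear on this position (hydrogen to chloro, hydrogen to bromo, chloro to bromo) each stayed within the scatter, so no step beyond the scatter is expected here either. The estimate for compound 4 is 85000 nM, range 45000 nM to 160000 nM, which amounts to an expected step of a 1.1-fold lower number from compound 3 to compound 4 (0.04 log units; within the scatter).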

Compound 4, half-maximal inhibitory concentration: 84600 nM
Compound 4: the middle estimate sits 1.0-fold (0.00 log units) above what was measured; the range from low to high includes it.
By their numbers in this assay, from the lowest: compounds 2, 4, 1 and 3 (each within the scatter of the next).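

In this assay methyl in place of bromo gives a 1.1-fold lower number from compound 3 to compound 4 (0.04 log units; within the scatter) and methyl in place of chloro gives a 1.4-fold higher number from compound 2 to compound 4 (0.16 log units; within the scatter) while methyl in place of hydrogen gives a 1.0-fold lower number from compound 1 to compound 4 (0.01 log units; within the scatter). A carbon group on this aromatic carbon therefore stays within the scatter of the hydrogen, chloro and bromo compounds, so the flat picture no longer rests on halogens alone. No measured evidence accounts for this flatness. As far as these compounds go, whether an amine, a carboxylic acid or a longer chain at this place would give a step beyond the scatter stays open.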